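Four Analogues of One Core, Three at the Limit

The source may report more compounds than this note shows. Statements on the series, on what has been measured and on what is new or still open speak of the compounds shown alone.

Compound 1 `C=C1C[C@]23C[C@@]1(O)CC[C@H]2c1ccc(OS(=O)(=O)c2ccc(C)cc2)c(C)c1[C@@H]3Cn1cc(-c2ccc(OC)cc2)nn1` in a functional assay on SW480 cells (Homo sapiens) for cytotoxicity, read by MTT assay, with a stated time of 4 days (on this read-out lower numbers stand for stronger inhibition and higher numbers for weaker inhibition), gives > 20000 nM, which is a limit of the assay and not a number.
Compound 2 `C=C1C[C@]23C[C@@]1(O)CC[C@H]2c1ccc(OS(=O)(=O)c2ccc(C)cc2)c(C)c1[C@@H]3Cn1cc(-c2ccc(F)cc2)nn1` in this assay gives > 20000 nM, again a limit.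
Compound 3 `C=C1C[C@]23C[C@@]1(O)CC[C@H]2c1ccc(O)c(C)c1[C@@H]3Cn1cc(-c2ccc(F)cc2)nn1` in this assay gives > 20000 nM, also a limit.

All three compounds share one core and differ in two places. Compound 2 and compound 3 differ in the core itself: hydrogen in place of (4-methylphenyl)sulfonyl on an oxygen on an aromatic ring. The step that the two limits leave unreadable from compound 2 to compound 3 cannot be sized, since both compounds sit at the limit of > 20000 nM in this assay, at which 3 of the 3 values shown sit. Compound 2 and compound 1 differ in the ring attached to the triazole: methoxy in place of fluoro on an aromatic carbon. The step that the two limits leave unreadable from compound 2 to compound 1 is likewise unreadable because both values sit at the limit of > 20000 nM in this assay, at which 3 of the 3 values shown sit.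

Compound 4 `C=C1C[C@]23C[C@@]1(O)CC[C@H]2c1ccc(O)c(C)c1[C@@H]3Cn1cc(-c2ccc(OC)cc2)nn1` has not yet been measured. It differs from compound 3 by methoxy in place of fluoro on an aromatic carbon, the same change that separates compound 2 from compound 1, at the same place. Each measured example of either change has left the compounds at the limit, so the step that the limit leaves unreadable from compound 3 to compound 4 is expected to be small or unreadable. This expectation rests on compound 3, which in this assay gives > 20000 nM, a limit. It also rests on the step that the two limits leave unreadable from compound 2 to compound 1, which left both compounds at the limit of > 20000 nM in this assay, at which 3 of the 3 values shown sit. Compound 4 is therefore expected to give about 30000 nM in this assay. The expected range for compound 4 runs from 15000 nM to 80000 nM, most likely reported only as a limit.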

Compound 4, half-maximal inhibitory concentration: > 20000 nM
Compound 4: only a limit was reported; the forecaster's own chance of this, stated with the estimate: 85%; the middle value does not contradict the limit.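

In this assay compound 4 gives > 20000 nM, a limit of the assay and not a number. The steps joining compound 4 to compound 3 and to compound 1 cannot be read, because all four compounds share one ceiling: the limit of > 20000 nM in this assay, at which 4 of the 4 values shown sit.

The compounds shown leave open how strongly any of them acts on these cells, and whether either change, fluoro to methoxy or loss of the (4-methylphenyl)sulfonyl group, alters that at all.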